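Hydroxy to methoxy in the series

A few compounds are considered here, and "the series" means these few. Any claim that something is new, unique, unknown or untested is made for them only; others in the source may bear on it.

Measured so far in a functional assay on HL-60 cells (Homo sapiens) for cytotoxicity, read by WST assay, with a stated time of 48 h; a higher number here means that more compound is needed for the effect, a lower number that less compound is needed
- compound 1 `COc1cccc(C[C@H]2C(=O)OC[C@@H]2Cc2ccccc2)c1` gives 66000 nM
- compound 2 `COc1ccc(C[C@H]2C(=O)OC[C@@H]2Cc2ccccc2)cc1` gives 67000 nM
- compound 3 `COc1cc(C[C@H]2C(=O)OC[C@@H]2Cc2ccccc2)ccc1O` gives 93000 nM

Compound 3 lies within the scatter of both compound 1 and compound 2, so the three cannot be ranked. Compound 4 `COc1ccc(C[C@H]2C(=O)OC[C@@H]2Cc2ccccc2)cc1OC` differs from compound 3 by hydroxy to methoxy (methyl in place of hydrogen on an oxygen on an aromatic ring), that is, methyl in place of hydrogen on an oxygen on an aromatic ring. Among the measured compounds shown here, no measured step makes this exact change. The nearest evidence, a 1.4-fold higher number from compound 1 to compound 3 (0.15 log units; within the scatter), places hydroxy in place of hydrogen on an aromatic carbon and bears on it only indirectly. No shift beyond the scatter is therefore expected in this assay. The expected size is a 1.3-fold lower number from compound 3 to compound 4 (0.12 log units; within the scatter), an estimate only. For compound 4 the estimated value is 70000 nM, with an expected range from 30000 nM to 140000 nM.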

Compound 4, half-maximal effective concentration: > 100000 nM
Compound 4 gave a limit, no number; the forecaster's own chance of this, stated with the estimate: 10%; middle value at least 1.4-fold (0.15 log units) away from the limit.
By their numbers in this assay, from the lowest: compounds 1, 2 and 3 (each within the scatter of the next). At a limit, above all of these: compound 4.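

In this assay, among the compounds shown here, compound 4 is the first compound to read as a limit, not a number: the limit of > 100000 nM in this assay, at which 1 of the 4 values shown sits. Methyl on the oxygen on the aromatic ring gives an at least 1.0-fold higher number from compound 3 to compound 4 (0.03 log units; that floor lies within the scatter), while the added methoxy gives an at least 1.4-fold higher number from compound 2 to compound 4 (0.17 log units; that floor lies within the scatter) and an at least 1.5-fold higher number from compound 1 to compound 4 (0.18 log units; that floor lies within the scatter). For the compounds shown here, all three are floors, so none establishes a shift beyond the scatter, yet capping this hydroxy brings no step to a lower number.

Going by these compounds, the true distance of compound 4 from compound 1, compound 2 and compound 3 remains open. So does the reading of an amine or a carboxylic acid at this position.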